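Aryl sulfonate anilides: varying the amide acyl group

The source may hold more compounds than are shown below. What is called first, only, known or untested is meant among the compounds shown, and "the series" means these compounds.

Measured compounds:
Compound 1, `CC(C)c1ccccc1OS(=O)(=O)c1cccc(NC(=O)CCl)c1`: 2200 nM
Compound 2, `CC(=O)Nc1ccc(S(=O)(=O)Oc2ccccc2C(C)C)cc1`: 16000 nM
Compound 3, `CC(=O)Nc1ccc(S(=O)(=O)Oc2ccccc2I)cc1`: 27000 nM

In a functional assay on MCF7 cells (Homo sapiens) for antiproliferative activity, read by sulforhodamine B assay, with a stated time of 48 h (a lower number here means a stronger inhibitor, a higher number a weaker inhibitor), compound 3 gives 27000 nM, the highest number among the three measured compounds. Compound 2 gives 16000 nM, and the step of a 1.7-fold higher number from compound 2 to compound 3 (0.23 log units; within the scatter) lies within the scatter. Among the measured compounds shown here, compound 1 gives 2200 nM; no single-place step links it to compound 3. Compound 4, `CC(C)C(=O)Nc1ccc(S(=O)(=O)Oc2ccccc2I)cc1`, differs from compound 3 by isopropyl in place of methyl on a carbonyl carbon. For the measured compounds named here, no measured step alters the group on the carbonyl carbon, so nothing measured bears directly on this change; the only single-place step in the set concerns a substituent on an aromatic carbon. Without a guide, the step of a 1.2-fold lower number from compound 3 to compound 4 (0.09 log units; within the scatter) is expected to stay within the scatter. Compound 4 is therefore estimated at 22000 nM, with a range from 8000 nM to 60000 nM.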

Compound 4, half-maximal inhibitory concentration: 8100 nM
For compound 4 the middle estimate is 2.7-fold (0.43 log units) above the measured one; the range from low to high includes it.
By their numbers in this assay, from the lowest: compound 1; then compounds 4, 2 and 3 (each within the scatter of the next, the first and the last beyond it).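

In this assay, among the compounds shown here, the group on the carbonyl carbon matters: isopropyl in place of methyl gives a 3.3-fold lower number from compound 3 to compound 4 (0.52 log units; beyond the scatter), whereas the only earlier single-place step, a 1.7-fold higher number from compound 2 to compound 3 (0.23 log units; within the scatter), concerned an aromatic carbon and stayed within the scatter. This effect rests on a single pair, both members carrying iodo on the aromatic carbon. Nothing available explains the step.

From the compounds shown here alone, whether the change carries over to the isopropyl aromatic substituent of compound 2 remains open. So does the outcome with a longer chain or an amine on the carbonyl carbon.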